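The compounds below may be only part of what the source reports. "The series", "measured", "known", "first", "only" and "open" are said of these compounds alone.

Going by the values given here, compound 3 `Cc1ccc(COc2ccc(C(=O)NC(=O)Nc3ccc(Cl)c(-c4nc5ccccc5[nH]4)c3)cc2)cc1` stands at the weak end of the series so far: in a functional assay on MGC-803 cells (Homo sapiens) for inhibition, read by MTT assay, with a stated time of 48 h (a higher number here means a weaker inhibitor, a lower number a stronger inhibitor), compound 3 gives 3860 nM, the highest of the three numbers. Compound 2 `O=C(NC(=O)c1ccc(OCc2ccccc2F)cc1)Nc1ccc(Cl)c(-c2nc3ccccc3[nH]2)c1` gives 120 nM in this assay, and compound 1 `Cc1ccc(NC(=O)NC(=O)c2ccc(OCc3ccc(F)cc3)cc2)cc1-c1nc2ccccc2[nH]1` gives 160 nM. Among the compounds with values here, the only measured step within the benzyl ether, a 32-fold higher number from compound 2 to compound 3 (1.51 log units; beyond the scatter), is the largest change in the set. Compound 4 `O=C(NC(=O)c1ccc(OCc2ccc(F)cc2)cc1)Nc1ccc(Cl)c(-c2nc3ccccc3[nH]2)c1` differs from compound 3 by fluoro in place of methyl on an aromatic carbon. Compound 1 already carries the same 4-fluorobenzyl ether on a core that differs from compound 4 elsewhere, and compound 1 gives 160 nM. A large drop in the number is therefore expected, about a 21-fold lower number from compound 3 to compound 4 (1.33 log units; beyond the scatter), because compound 1 gives 160 nM. Compound 4 is estimated at 180 nM, within 70 nM to 500 nM.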

Compound 4, half-maximal inhibitory concentration: 61 nM
The estimate for compound 4 lay 3.0-fold (0.47 log units) above the measured number; measured number below the stated range.
By their numbers in this assay, from the lowest: compounds 4, 2 and 1 (each within the scatter of the next, the first and the last beyond it); then compound 3.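

On the aromatic carbon para to a large group, fluoro in place of methyl gives a 63-fold lower number from compound 3 to compound 4 (1.80 log units; beyond the scatter), so the weak number goes with the methyl group and not with the benzyl ether as such. Changing 2-fluorophenyl to 4-fluorophenyl gives a 2.0-fold lower number from compound 2 to compound 4 (0.29 log units; within the scatter), so these two fluoro placings cannot be told apart. On the core, chloro in place of methyl gives a much smaller step, a 2.6-fold lower number from compound 1 to compound 4 (0.42 log units; beyond the scatter).

Nothing measured here gives a reason for the step from methyl to fluoro. On these data alone, whether chloro, methoxy or trifluoromethyl at this position reads with fluoro or with methyl stays open.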